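Dialkylamino series: from diethylamino to dibutylamino

The source may report more compounds than this note shows. Statements on the series, on what has been measured and on what is new or still open speak of the compounds shown alone.

Compound 1 `CCCOc1c(-c2cc(OC)c(OC)c(OC)c2)oc2ccccc2c1=O` at 11800 nM
Compound 2 `CCN(CC)CCCOc1c(-c2cc(OC)c(OC)c(OC)c2)oc2ccccc2c1=O` at 13600 nM

Within the data shown here, in a functional assay on PC-3 cells (Homo sapiens) for antiproliferative activity, read by WST assay, with a stated time of 3 days (on this read-out higher numbers stand for weaker inhibition and lower numbers for stronger inhibition), compound 2 stands at 13600 nM and lies within the scatter of compound 1 at 11800 nM on the only two numbers available. Compound 3 `CCCCN(CCCC)CCCOc1c(-c2cc(OC)c(OC)c(OC)c2)oc2ccccc2c1=O` carries dibutylamino in place of diethylamino on a saturated chain carbon, three bonds along the chain from an oxygen on an aromatic ring. Among the measured compounds shown here, the one measured step bearing on this is a 1.2-fold higher number from compound 1 to compound 2 (0.06 log units; within the scatter) for diethylamino in place of hydrogen at that same place, so no step beyond the scatter is expected in this assay here. For the measured compounds named here, no measurement yet covers dibutylamino, so the range is kept wide. The estimated step is a 1.4-fold lower number from compound 2 to compound 3 (0.13 log units; within the scatter) on this reading. For compound 3 the estimated value is 10000 nM with an expected range from 3500 nM to 22000 nM for now.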

Compound 3, half-maximal inhibitory concentration: 7100 nM
Beside the measured number, compound 3's estimate is 1.4-fold (0.15 log units) above it; low and high end bracket the measured number.
By their numbers in this assay, from the lowest: compounds 3, 1 and 2 (each within the scatter of the next).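

In this assay, dibutylamino in place of diethylamino on this saturated chain carbon gives a 1.9-fold lower number from compound 2 to compound 3 (0.28 log units; within the scatter), so a group of 9 heavy atoms entering for one of 5 still produces no step beyond the scatter. Measured against hydrogen at the same place, dibutylamino gives a 1.7-fold lower number from compound 1 to compound 3 (0.22 log units; within the scatter), which means that hydrogen and both dialkylamino groups are now covered at this position without a step that can be read as a real difference. No evidence bearing on this result is at hand.

Going by these compounds, whether a ring amine such as piperidine or morpholine, or a primary amine, at this place would give a step beyond the scatter remains open. On these data alone, a longer chain carrying the dibutylamino group is equally open, as is any effect of these groups outside this one cell line.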